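The source may hold more compounds than are shown below. What is called first, only, known or untested is meant among the compounds shown, and "the series" means these compounds.

Working notes on the series, all read in a functional assay on HepG2 cells (Homo sapiens) for antiproliferative activity, read by MTT assay, with a stated time of 72 h; a lower number here means a stronger inhibitor, a higher number a weaker inhibitor. Compound 1 `COc1cccc(N2C(=O)COc3ccc(-c4cnc(Cl)c(NS(=O)(=O)c5ccc(F)cc5)c4)cc32)c1` gives > 40000 nM, which is a limit of the assay and not a number. Compound 2 `O=C1COc2ccc(-c3cccc(NS(=O)(=O)c4ccc(F)cc4)c3)cc2N1` gives > 40000 nM, also a limit. Compound 3 `COc1ncc(-c2ccc3c(c2)NC(=O)CO3)cc1NS(=O)(=O)c1ccc(F)cc1` gives a measured 6590 nM. Compound 1 thus stands at the limit of > 40000 nM in this assay, at which 2 of the 3 values shown sit.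

The next step leads to compound 4 `COc1ccc(N2C(=O)COc3ccc(-c4cnc(Cl)c(NS(=O)(=O)c5ccc(F)cc5)c4)cc32)cc1`, which carries 4-methoxyphenyl in place of 3-methoxyphenyl on an amide-type nitrogen in a ring. Among the measured compounds shown here, no measured pair shows a change of this kind, so this assay offers no direct guide to its size, and no shift beyond the usual scatter is expected in either direction. The expectation rests on compound 1 and its limit of > 40000 nM. The expected step is a number no higher from compound 1 to compound 4 (the limit leaves the size open), and compound 4 may well be reported only as a limit. For compound 4 the estimate is 40000 nM, with an expected range from 15000 nM to 80000 nM.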

Compound 4, half-maximal inhibitory concentration: > 40000 nM
Compound 4: only a limit was reported; the forecaster's own chance of this, stated with the estimate: 60%; the middle value lies on the limit itself.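

Compound 1 and compound 4 are both reported only as limits, so no step can be read between them: the limit of > 40000 nM in this assay, at which 3 of the 4 values shown sit. The compounds shown leave open whether 4-methoxyphenyl and 3-methoxyphenyl differ at all on the amide-type nitrogen in a ring.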